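Chloro in Place of Fluoro: Reading One Step to Predict Another

The source may hold more compounds than are shown below. What is called first, only, known or untested is meant among the compounds shown, and "the series" means these compounds.

Four compounds share a common core and differ at one outer aromatic ring. Three have been tested in a functional assay on LOX IMVI cells (Homo sapiens) for cytotoxicity, read by MTT assay, with a stated time of 24 h; a lower number here means a stronger inhibitor, a higher number a weaker inhibitor. Compound 1, `COc1cc(-c2nc(-c3ccccc3)[nH]c2-c2ccnc(NCCCNS(=O)(=O)c3cccc4ccccc34)n2)ccc1F`, gives 14900 nM in this assay. Compound 2, `COc1cc(-c2nc(-c3ccccc3)[nH]c2-c2ccnc(NCCCNS(=O)(=O)c3cccc4ccccc34)n2)ccc1Cl`, gives 13500 nM in this assay. The change between them is chloro in place of fluoro on an aromatic carbon, and it made a 1.1-fold lower number from compound 1 to compound 2 (0.04 log units; within the scatter). Compound 3, `O=S(=O)(NCCCNc1nccc(-c2[nH]c(-c3ccccc3)nc2-c2ccc(F)c(O)c2)n1)c1ccccc1`, gives 9580 nM in this assay; the difference between its core and the core of compound 1 is not broken down here, and its number sits within the scatter of the other two.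

Compound 4, `O=S(=O)(NCCCNc1nccc(-c2[nH]c(-c3ccccc3)nc2-c2ccc(Cl)c(O)c2)n1)c1ccccc1`, has not yet been measured. It differs from compound 3 by chloro in place of fluoro on an aromatic carbon. Among the measured compounds shown here, this is the same kind of change as the one from compound 1 to compound 2, but not the same: in the first pair the aromatic carbon is ortho to a methoxy group, in the second pair it is ortho to a hydroxy group, while both are para to a large group.

Because a 1.1-fold lower number from compound 1 to compound 2 (0.04 log units; within the scatter) stayed within the scatter, a similarly small step is expected here, estimated as a 1.1-fold lower number from compound 3 to compound 4 (0.04 log units; within the scatter). On that basis compound 4 is expected to give about 8800 nM in this assay, with a likely range from 4500 nM to 17500 nM.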

Compound 4, half-maximal inhibitory concentration: 2630 nM
For compound 4 the middle estimate is 3.3-fold (0.52 log units) above the measured one, outside the stated range (below it).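

In this assay, chloro in place of fluoro gave a 3.6-fold lower number from compound 3 to compound 4 (0.56 log units; beyond the scatter), so a step that was too small to read on one core became a clear gain on the other. The change therefore has no single size in this series, and a near-zero step on one core is a poor guide to its size on another: the same change on two cores in this assay, a 1.1-fold lower number (0.04 log units; within the scatter) from compound 1 to compound 2 and a 3.6-fold lower number (0.56 log units; beyond the scatter) from compound 3 to compound 4, 3.3-fold (0.52 log units) apart, beyond the scatter of two such steps

This does not show which difference between the cores separates the two steps, since the methoxy group of the first pair and the hydroxy group of the second are only one visible difference, the cores are not broken down further, and two pairs cannot establish a rule.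

The compounds shown leave open whether the larger step belongs to the hydroxy group itself, which a pair carrying that group on the core of compound 1 could test. They also leave open whether bromo in the same place would lower the number further than chloro, and whether the step would survive with an amine or a carboxylic acid in place of the hydroxy group.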